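The compounds below may be only part of what the source reports. "The series", "measured", "known", "first", "only" and "open" are said of these compounds alone.

In an ADME assay on HEK293 cells (Homo sapiens) for cytotoxicity, read by MTT assay (on this read-out higher numbers stand for weaker inhibition and lower numbers for stronger inhibition), compound 2 (`Cc1cc(O)c(C(=O)/C=C/c2cccc(C(F)(F)F)c2)c(=O)o1`) stands at > 100000 nM, which is a limit of the assay and not a number. Its nearest measured neighbour is compound 1 (`Cc1cccc(/C=C/C(=O)c2c(O)cc(C)oc2=O)c1`), and in this assay compound 1 gives 100000 nM as a true reading. For the measured compounds named here, only one measured step bears on what follows: a number no lower from compound 1 to compound 2 (the limit leaves the size open). Its size cannot be read, and for compound 2 the picture is bounded by the limit of > 100000 nM in this assay, at which 1 of the 2 values shown sits, in the data so far. Compound 3 (`Cc1cc(O)c(C(=O)/C=C/c2cccc(O)c2)c(=O)o1`) carries hydroxy in place of trifluoromethyl on an aromatic carbon, meta to a large group (hydroxy in place of trifluoromethyl on an aromatic carbon). Going by the values given here, no measured step involves a hydroxy group, so the expectation rests on the neighbouring compounds alone. Since compound 1 reads 100000 nM and compound 2 gives no number, no clear shift is expected in this assay beyond the scatter. Another limit reading would be no surprise. Expected in this comparison is an at least 1.1-fold lower number from compound 2 to compound 3 (0.04 log units; that floor lies within the scatter). For compound 3 the estimated value is 90000 nM, with an expected range from 35000 nM to 200000 nM in this assay.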

Compound 3, half-maximal inhibitory concentration: > 100000 nM
Compound 3: no number, only a limit (the forecaster's own chance of this, stated with the estimate: 50%); at least 1.1-fold (0.04 log units) between middle value and limit.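

In this assay compound 3 reads > 100000 nM, which is a limit of the assay and not a number. Hydroxy, which brings a hydrogen-bond donor and a hydrogen-bond acceptor where trifluoromethyl brought neither, thus gives no number at this place either, and the step between the two limit compounds cannot be read; what can be said is a number no lower from compound 1 to compound 3 (the limit leaves the size open). With two quite different replacements for methyl on this aromatic carbon now ending the same way, the series sits mostly at one edge of the measurable range, and the change of group shows no readable effect on the read-out: the limit of > 100000 nM in this assay, at which 2 of the 3 values shown sit.

On these data alone, whether any group at this place can bring a true reading lower than that of compound 1 stays open, as an amine, a carboxylic acid or a longer chain here might or might not do so. As far as these compounds go, how far compound 2 and compound 3 actually differ from compound 1 also stays open, as does whether a change elsewhere on the shared core would matter more than one at this place.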